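A few compounds are considered here, and "the series" means these few. Any claim that something is new, unique, unknown or untested is made for them only; others in the source may bear on it.

In an ADME assay on L6 cells (Rattus norvegicus) for cytotoxicity, read by resazurin assay, with a stated time of 72 h (on this read-out lower numbers stand for stronger inhibition and higher numbers for weaker inhibition), compound 1 `CN1CCN(CC(=O)N2CC3C(c4ccccc4)CC(N(C)C)(CC3c3ccccc3)C2)CC1` gives 9250 nM, and compound 2 `CN1CCN(CCN2CC3C(c4ccccc4)CC(N(C)C)(CC3c3ccccc3)C2)CC1` gives 5260 nM. Going by the values given here, these two values lie within the scatter of each other, so compound 2 stands level with the only other compound measured so far. Compound 3 `CN1CCN(CCCN2CC3C(c4ccccc4)CC(N(C)C)(CC3c3ccccc3)C2)CC1` differs from compound 2 by one change: (4-methylpiperazin-1-yl)methyl in place of 4-methylpiperazin-1-yl on a saturated chain carbon, two bonds along the chain from an amine nitrogen in a ring. In other words, (4-methylpiperazin-1-yl)methyl stands in place of 4-methylpiperazin-1-yl on a saturated chain carbon, two bonds along the chain from an amine nitrogen in a ring. Among the compounds with values here, one measured step bears on this, at the same amine nitrogen: a 1.8-fold lower number from compound 1 to compound 2 (0.25 log units; within the scatter). That step did not alter the chain length alone, so the support is indirect, and no change beyond the scatter is expected in this assay. The expected step is a 1.1-fold lower number from compound 2 to compound 3 (0.04 log units; within the scatter). For compound 3 the estimate is 4800 nM, with a range from 2400 nM to 9500 nM.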

Compound 3, half-maximal inhibitory concentration: 200 nM
For compound 3 the middle estimate is 24-fold (1.38 log units) above the measured one; the measured number lies below the stated range.
By their numbers in this assay, from the lowest: compound 3; then compounds 2 and 1 (each within the scatter of the next).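

Lengthening the chain on the amine nitrogen in a ring from 2-(4-methylpiperazin-1-yl)ethyl to 3-(4-methylpiperazin-1-yl)propyl gives a 26-fold lower number from compound 2 to compound 3 (1.42 log units; beyond the scatter) in this assay, so this position, whose earlier step stayed within the scatter, responds strongly to this change. Measured against the ((4-methylpiperazin-1-yl)methyl)carbonyl group, the propyl-linked group gives a 46-fold lower number from compound 1 to compound 3 (1.67 log units; beyond the scatter), so among these three compounds only the 3-(4-methylpiperazin-1-yl)propyl group stands apart. Nothing available accounts for this large step.

The compounds shown leave open whether a longer chain, such as 4-(4-methylpiperazin-1-yl)butyl, would lower the number further or raise it again. They also leave open whether the large step depends on the 4-methylpiperazin-1-yl group, or would persist with a morpholine or a dimethylamino group at the end of the same propyl chain.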